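A few compounds are considered here, and "the series" means these few. Any claim that something is new, unique, unknown or untested is made for them only; others in the source may bear on it.

Three compounds of the series carry the same core and differ only in the group on the carbonyl carbon attached to the ring nitrogen. In a physicochemical assay for solubility (a higher number here means a more soluble compound, a lower number a less soluble compound), compound 1 `CC(C)(C)OC(=O)N1CCC[C@H]1C(=O)N1CCC(NS(=O)(=O)c2cc(S(=O)(=O)c3ccccc3)ccc2C(F)(F)F)CC1` gives 25000 nM. Compound 2 `CC(C)C(=O)N1CCC[C@H]1C(=O)N1CCC(NS(=O)(=O)c2cc(S(=O)(=O)c3ccccc3)ccc2C(F)(F)F)CC1` gives 100000 nM, and compound 3 `CN(C)CC(=O)N1CCC[C@H]1C(=O)N1CCC(NS(=O)(=O)c2cc(S(=O)(=O)c3ccccc3)ccc2C(F)(F)F)CC1` gives 100000 nM. The two measured steps away from compound 1 are alike: a 4.0-fold higher number from compound 1 to compound 2 (0.60 log units; beyond the scatter) and a 4.0-fold higher number from compound 1 to compound 3 (0.60 log units; beyond the scatter). Between the other two there is no change at the digits printed from compound 2 to compound 3 (within the scatter), so compound 3 stands level with compound 2, and the two together hold the highest numbers of the three, with compound 1 the furthest off.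

Compound 4 `O=C([C@@H]1CCCN1Cc1ccccc1)N1CCC(NS(=O)(=O)c2cc(S(=O)(=O)c3ccccc3)ccc2C(F)(F)F)CC1` is not yet measured. The change is benzyl in place of ((dimethylamino)methyl)carbonyl on an amine nitrogen in a ring. For the measured compounds named here, no measured step covers this change: every measured step exchanges one group for another on the carbonyl carbon and keeps the carbonyl, whereas here the whole ((dimethylamino)methyl)carbonyl leaves and benzyl enters on the amine nitrogen in the ring. The expectation therefore rests on little. The measured steps span a modest range, and a step of similar or somewhat larger size, downward, is the working expectation: a 2.5-fold lower number from compound 3 to compound 4 (0.40 log units; beyond the scatter). Compound 4 is estimated at 40000 nM, with a range from 10000 nM to 120000 nM.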

Compound 4, solubility: 25000 nM
Compound 4: the middle estimate sits 1.6-fold (0.20 log units) above what was measured, within the range that was stated.
By their numbers in this assay, from the lowest: compounds 1 and 4 (each within the scatter of the next); then compounds 2 and 3 (each within the scatter of the next).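

In this assay, for the compounds shown here, the first change at this amine nitrogen in the ring that removes the carbonyl gives a lower number, both against the ((dimethylamino)methyl)carbonyl group (a 4.0-fold lower number from compound 3 to compound 4 (0.60 log units; beyond the scatter)) and against isopropylcarbonyl (a 4.0-fold lower number from compound 2 to compound 4 (0.60 log units; beyond the scatter)). Against tert-butoxycarbonyl, benzyl shows no such difference (no change at the digits printed from compound 1 to compound 4 (within the scatter)), so the lower level is no longer unique to compound 1, and a group without a carbonyl reaches it too. Nothing available offers a reason for these differences.

Going by these compounds alone, with only one group lacking the carbonyl, the loss of the carbonyl cannot be told apart from the entry of the aromatic ring. A plain ethyl on the same nitrogen, a phenylacetyl group, or a benzyl carrying a dimethylamino group or a carboxylic acid would separate these two readings.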